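The source may report more compounds than this note shows. Statements on the series, on what has been measured and on what is new or still open speak of the compounds shown alone.

Among the compounds with values here, in a functional assay (spleen, spleen) for activation, with Mus musculus as the target (a higher number here means that more compound is needed for the effect, a lower number that less compound is needed), compound 1 `CNc1nc(N)c2nc(O)n(Cc3ccccc3)c2n1` gives 1 uM, the highest of the three numbers measured so far. The two other measured compounds share its core and differ from it only at one aromatic carbon. Compound 2 `CCCCc1nc(N)c2nc(O)n(Cc3ccccc3)c2n1` carries butyl there and gives 0.03 uM, while compound 3 `CCCCCOc1nc(N)c2nc(O)n(Cc3ccccc3)c2n1` carries pentyloxy and gives 0.01 uM. Both replacements of the methylamino group moved the number a long way: a 33-fold lower number from compound 1 to compound 2 (1.52 log units; beyond the scatter) and a 100-fold lower number from compound 1 to compound 3 (2.00 log units; beyond the scatter). Between the two larger groups the step was smaller: a 3.0-fold lower number from compound 2 to compound 3 (0.48 log units; beyond the scatter). Compound 4 `CCNc1nc(N)c2nc(O)n(Cc3ccccc3)c2n1` has not yet been measured. It differs from compound 1 in one place: methyl in place of hydrogen on a saturated chain carbon bound to a nitrogen on an aromatic ring. In other words, methylamino becomes ethylamino, a far smaller change than those leading to compound 2 or compound 3, though in the same spirit of adding carbon at that position. A lower number than that of compound 1 is expected for compound 4, but with a step well short of the large ones seen. The expected step is a 3.3-fold lower number from compound 1 to compound 4 (0.52 log units; beyond the scatter). Compound 4 is thus estimated at 0.3 uM, within a range from 0.08 uM to 1 uM.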

Compound 4, minimum effective concentration: 1 uM
Beside the measured number, compound 4's estimate is 3.3-fold (0.52 log units) below it, and the stated range covers the measured number.
By their numbers in this assay, from the lowest: compound 3; then compound 2; then compounds 1 and 4 (each within the scatter of the next).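

In this assay, going from methylamino to ethylamino gives no change at the digits printed from compound 1 to compound 4 (within the scatter), so a methyl added at this saturated chain carbon bound to a nitrogen on an aromatic ring does not shift the number beyond the scatter. The large gaps to the other two groups remain: a 100-fold higher number from compound 3 to compound 4 (2.00 log units; beyond the scatter) and a 33-fold higher number from compound 2 to compound 4 (1.52 log units; beyond the scatter), so a single added carbon on the methylamino group does not carry compound 4 toward the much lower numbers of the butyl and pentyloxy compounds. Nothing available here explains why these groups differ so much.

From the compounds shown here alone, whether a longer chain on the nitrogen, such as butylamino, would also leave the number unchanged remains open. Pentylamino would test whether the linking atom or the chain length matters more, since it keeps the pentyl chain of compound 3 but joins it through nitrogen instead of oxygen.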